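Compound 3 to compound 4: swapping ethynyl for 4-chlorophenyl

The compounds below may be only part of what the source reports. "The series", "measured", "known", "first", "only" and "open" are said of these compounds alone.

Measured in a functional assay on MDA-MB-231 cells (Homo sapiens) for antiproliferative activity, read by MTT assay, with a stated time of 72 h; a lower number here means a stronger inhibitor, a higher number a weaker inhibitor:
Compound 1 `O=C(CCc1cccc2c1B(O)OC2)NCc1ccccc1`: > 100000 nM (a limit of the assay)
Compound 2 `CC(C)c1cccc(NC(=O)CCc2cccc3c2B(O)OC3)c1`: 1600 nM
Compound 3 `C#Cc1cccc(NC(=O)CCc2cccc3c2B(O)OC3)c1`: 1600 nM

Compound 3 stands level with compound 2, its nearest neighbour on these numbers. The remaining value, that of compound 1, is a limit and not a number (the limit of > 100000 nM in this assay, at which 1 of the 3 values shown sits).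

Compound 4 `O=C(CCc1cccc2c1B(O)OC2)Nc1cccc(-c2ccc(Cl)cc2)c1` has 4-chlorophenyl in place of ethynyl on an aromatic carbon, meta to a large group (4-chlorophenyl in place of ethynyl on an aromatic carbon).

Among the measured compounds shown here, one measured step bears on this change, at the same place on the molecule: no change at the digits printed from compound 2 to compound 3 (within the scatter). That exchange of isopropyl for ethynyl left the value unmoved. For the measured compounds named here, no measured step brings in 4-chlorophenyl, however, so the expectation remains uncertain and the range is kept wide.

No clear shift in either direction is expected, and the estimated step is a 1.3-fold lower number from compound 3 to compound 4 (0.12 log units; within the scatter). In this assay, the estimated value for compound 4 is 1200 nM, with an expected range from 300 nM to 5000 nM.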

Compound 4, half-maximal inhibitory concentration: 260 nM
Compound 4: the middle estimate sits 4.6-fold (0.66 log units) above what was measured; the whole stated range lies above it.
By their numbers in this assay, from the lowest: compound 4; then compounds 2 and 3 (each within the scatter of the next). At a limit, above all of these: compound 1.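

In this assay, this position proves able to move the value, which the exchange of isopropyl for ethynyl had not shown: 4-chlorophenyl is the first group here to give a step beyond the scatter (a 6.2-fold lower number from compound 3 to compound 4 (0.79 log units; beyond the scatter)). The step from the isopropyl compound has the same size (a 6.2-fold lower number from compound 2 to compound 4 (0.79 log units; beyond the scatter)), so among the three groups compared at this carbon, only 4-chlorophenyl stands apart, while the other two remain level. Nothing measured here accounts for this step.

The compounds shown leave open whether the aromatic ring alone carries the step or the chlorine is needed, a question that a plain phenyl would address. They also leave open how a saturated ring such as cyclohexyl, or a phenyl bearing an amine or a carboxylic acid, would behave at this carbon.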